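The source may hold more compounds than are shown below. What is called first, only, known or untested is meant among the compounds shown, and "the series" means these compounds.

Of the compounds shown here, three sharing one core have been measured in an ADME assay on microsomes from liver (Homo sapiens) for metabolic stability, tested at 2.5 uM; a lower number here means slower removal, a higher number faster removal of the compound. Compound 1 `COc1ccc(-c2c(S(=O)(=O)c3cc(F)cc(F)c3)cnc3cc(F)ccc23)cc1` gives 1.51 mL/min. Compound 2 `COc1cccc(-c2c(S(=O)(=O)c3cc(F)cc(F)c3)cnc3cc(F)ccc23)c1` gives 1.81 mL/min, and the step of a 1.2-fold higher number from compound 1 to compound 2 (0.08 log units; within the scatter) lies within the scatter, so these two numbers cannot be told apart. Compound 3 `O=S(=O)(c1cc(F)cc(F)c1)c1cnc2cc(F)ccc2c1-c1ccc(Cl)cc1` gives 0.03 mL/min, a far lower number: the step of a 50-fold lower number from compound 1 to compound 3 (1.70 log units; beyond the scatter) and the step of a 60-fold lower number from compound 2 to compound 3 (1.78 log units; beyond the scatter) are both large. Among the three, compound 2 therefore sits at the high end together with compound 1, and well away from compound 3.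

Compound 4 `COc1cccc(-c2c(S(=O)(=O)c3ccc(F)c(F)c3)cnc3cc(F)ccc23)c1` has not yet been measured. It differs from compound 2 by 3,4-difluorophenyl in place of 3,5-difluorophenyl on a sulfonyl sulfur. Among the compounds with values here, none of the measured steps touches this part of the molecule: each of them swaps 4-methoxyphenyl, 3-methoxyphenyl or 4-chlorophenyl on an aromatic carbon, or chloro for methoxy there, and none alters the group on the sulfonyl sulfur. Within the data shown here, there is thus no measured step that bears directly on the change from compound 2 to compound 4, and the ring that leaves and the ring that enters are counted as the same atoms joined differently. The expectation is therefore a step of a 1.0-fold lower number from compound 2 to compound 4 (0.00 log units; within the scatter), no further than the scatter. In this assay compound 4 is expected to give 1.8 mL/min, within a range from 0.9 mL/min to 3.6 mL/min.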

Compound 4, intrinsic clearance in a liver preparation (reported as CLH), per the amount of preparation that the assay uses: 1.77 mL/min
Beside the measured number, compound 4's estimate is 1.0-fold (0.01 log units) above it; the range from low to high includes it.
By their numbers in this assay, from the lowest: compound 3; then compounds 1, 4 and 2 (each within the scatter of the next).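

Moving one fluorine on the ring attached to the sulfonyl sulfur, with 3,4-difluorophenyl in place of 3,5-difluorophenyl, gives the step of a 1.0-fold lower number from compound 2 to compound 4 (0.01 log units; within the scatter) in this assay and so leaves two numbers that cannot be told apart. Within the data shown here, this is the first view of the group on the sulfonyl sulfur, as the earlier steps all concerned the group on the aromatic carbon, where the step of a 50-fold lower number from compound 1 to compound 3 (1.70 log units; beyond the scatter) is large, whereas this rearrangement of the same atoms on the sulfonyl sulfur produces no step beyond the scatter. Nothing measured here accounts for the match between these two difluorophenyl arrangements.

As far as these compounds go, what stays open is how the number in this assay would respond to a different kind of group on the sulfonyl sulfur, such as a plain phenyl ring, a pyridine ring, a morpholine or a short alkyl chain. Also open, from the compounds shown here alone, is whether the same fluorine rearrangement would leave the number as steady with the 4-chlorophenyl group of compound 3 in place, where the starting value for compound 3 is only 0.03 mL/min in the same assay.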